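Amide exchange in a series held at its limit

A few compounds are considered here, and "the series" means these few. Any claim that something is new, unique, unknown or untested is made for them only; others in the source may bear on it.

Measured in a functional assay on FaDu cells (Homo sapiens) for antiproliferative activity, read by sulforhodamine B assay, with a stated time of 48 h; a lower number here means a stronger inhibitor, a higher number a weaker inhibitor (each entry is a limit and not a number):
compound 1 `COc1ccc(-c2oc3c(OC)c(OC)cc(OCCCC(=O)NCc4ccccn4)c3c(=O)c2O)cc1` gives > 40000 nM as a limit
compound 2 `COc1ccc(-c2oc3c(OC)c(OC)cc(OCCCC(=O)N4CCN(C)CC4)c3c(=O)c2O)cc1` gives > 40000 nM as a limit
compound 3 `CCCCCN(C)C(=O)CCCCCOc1cc(OC)c(OC)c2oc(-c3ccc(OC)cc3)c(O)c(=O)c12` gives > 40000 nM as a limit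

Compound 3 has only a limit, > 40000 nM, and no number. It stands with the other two compounds: the limit of > 40000 nM in this assay, at which 3 of the 3 values shown sit.

The next compound is compound 4 `COc1ccc(-c2oc3c(OC)c(OC)cc(OCCCCCC(=O)NCc4ccccn4)c3c(=O)c2O)cc1`. It differs from compound 3 at the amide: ((pyridin-2-yl)methyl)amino in place of methyl(pentyl)amino on a carbonyl carbon. In short, ((pyridin-2-yl)methyl)amino stands in place of methyl(pentyl)amino on a carbonyl carbon. Compound 1 already carries the entering group, so the closest evidence is a step that the two limits leave unreadable from compound 1 to compound 3, although the chain differs there as well. Neither a step that the two limits leave unreadable from compound 1 to compound 2 nor a step that the two limits leave unreadable from compound 2 to compound 3 supplies a size.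

With no readable size to carry over, no direction is assumed and nothing beyond the scatter is expected. The expected change is a number no higher from compound 3 to compound 4 (the limit leaves the size open). For compound 4 the estimate is 40000 nM, with an expected range of 15000 nM to 80000 nM, and another limit is the likeliest report.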

Compound 4, half-maximal inhibitory concentration: > 40000 nM
Compound 4: a limit, no number (the forecaster's own chance of this, stated with the estimate: 75%); the middle value lies on the limit itself.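

Compound 4 gives > 40000 nM as a limit, so no step linking it to compound 1, compound 2 or compound 3 can be read, and this assay shows one shared result: the limit of > 40000 nM in this assay, at which 4 of the 4 values shown sit.

The compounds shown leave open whether any amide or chain in this series gives a measurable value.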